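From 4-nitrophenyl to 2,3-dimethylphenyl: what to expect

This account rests on a few compounds, and the source may have more. Where it says the series, first, only, none or still open, it means among the compounds named here.

Compound 1 `COc1cc(-n2cnc3ccc(-c4ccc([N+](=O)[O-])cc4)cc32)cc(OC)c1OC` gives 740 nM
Compound 2 `COc1cc(-n2cnc3ccc(-c4ccccc4)cc32)cc(OC)c1OC` gives 2290 nM

In a functional assay on MCF7 cells (Homo sapiens) for antiproliferative activity, read by MTT assay, with a stated time of 72 h (a higher number here means a weaker inhibitor, a lower number a stronger inhibitor), compound 1 has the lower of the two numbers, which makes it the stronger inhibitor of the pair. Compound 3 `COc1cc(-n2cnc3ccc(-c4cccc(C)c4C)cc32)cc(OC)c1OC` has not yet been measured and differs from compound 1 in one place (2,3-dimethylphenyl in place of 4-nitrophenyl on an aromatic carbon). Going by the values given here, one measured step bears on this change (a 3.1-fold higher number from compound 1 to compound 2 (0.49 log units; beyond the scatter)). It puts hydrogen in place of nitro, and it is modest but beyond the scatter. Compound 3 carries no nitro group either, so in this assay a step of similar size towards a higher number is expected, landing near compound 2 at 2290 nM as a guide. Among the compounds with values here, no measured compound carries the two methyl groups, so the range stays wide on both sides. The estimated step (a 3.1-fold higher number from compound 1 to compound 3 (0.49 log units; beyond the scatter)) rests on that single comparison. For compound 3 the expected value is 2300 nM (estimated range 800 nM to 7000 nM).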

Compound 3, half-maximal inhibitory concentration: 2150 nM
For compound 3 the middle estimate is 1.1-fold (0.03 log units) above the measured one; measured number inside the range.
By their numbers in this assay, from the lowest: compound 1; then compounds 3 and 2 (each within the scatter of the next).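

In this assay, 2,3-dimethylphenyl in place of phenyl on this aromatic carbon gives a 1.1-fold lower number from compound 2 to compound 3 (0.03 log units; within the scatter) and so does not separate the two compounds. Going from 4-nitrophenyl to 2,3-dimethylphenyl gives a 2.9-fold higher number from compound 1 to compound 3 (0.46 log units; beyond the scatter) and matches the earlier loss seen on removing the nitro group, so among these three compounds only compound 1, the one carrying nitro, stands apart from the others. No measurement is available here to explain this difference.

On these data alone, it remains open whether the lower number of compound 1 is special to nitro or would also appear with another group in its place, such as an amine, a nitrile or a carboxylic acid. As far as these compounds go, the effect of a single methyl group on the phenyl ring also remains unknown, since the two methyl groups appear here only together.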